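Swapping the Aryl Tail: Expected Cytotoxicity of Compound 4

The source may hold more compounds than are shown below. What is called first, only, known or untested is meant among the compounds shown, and "the series" means these compounds.

Measured so far:
- compound 1 `CCCCCN1CCc2nc(C)c(C(OC(C)(C)C)C(=O)O)c(-c3ccc(C)cc3)c2C1` — in an ADME assay on MT2 cells (Homo sapiens) for cytotoxicity, read by XTT assay, with a stated time of 4 days (on this read-out lower numbers stand for higher toxicity in this test and higher numbers for lower toxicity in this test), compound 1 gives > 40000 nM, which is a limit of the test rather than a number.
- compound 2 `Cc1nc2c(c(-c3cc(F)c4c(c3C)CCCO4)c1[C@H](OC(C)(C)C)C(=O)O)CN(CCCc1cccc(F)c1)CC2` — compound 2 gives > 40000 nM, again only a limit.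
- compound 3 `Cc1ccc(-c2c3c(nc(C)c2[C@H](OC(C)(C)C)C(=O)O)CCN(C(=O)NCc2ccccc2)C3)cc1` — compound 3 gives > 40000 nM, once more a limit.

Compound 2 therefore stands exactly where the other two measured compounds stand: no toxicity was seen up to the top of the tested range, and the limit of > 40000 nM in this assay, at which 3 of the 3 values shown sit, is all the data show. For the measured compounds named here, no pair of measured compounds differs in a single place, so no measured step is available to learn from.

Compound 4 `Cc1ccc(CCCN2CCc3nc(C)c([C@H](OC(C)(C)C)C(=O)O)c(-c4cc(F)c5c(c4C)CCCO5)c3C2)cc1` is the next candidate. It differs from compound 2 in one spot: 4-methylphenyl in place of 3-fluorophenyl on a saturated chain carbon, three bonds along the chain from an amine nitrogen in a ring. The change trades a fluorine-bearing ring for a methyl-bearing ring at the far end of the saturated chain, while the rest of compound 2 is kept intact.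

Given that every measured compound sits at the limit, no step beyond the usual scatter is expected from compound 2 to compound 4, that is, a number no higher from compound 2 to compound 4 (the limit leaves the size open) in this assay. Compound 4 is expected to give about 40000 nM, within 20000 nM to 80000 nM, most likely again reported only as a limit.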

Compound 4, half-maximal cytotoxic concentration: > 40000 nM
Compound 4 was reported as a limit; the forecaster's own chance of this, stated with the estimate: 85%; the middle value lies on the limit itself.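

Compound 2 and compound 4 are both reported only as limits, not as numbers, so no step between them can be read: the limit of > 40000 nM in this assay, at which 4 of the 4 values shown sit.

The compounds shown leave open whether 4-methylphenyl in place of 3-fluorophenyl changes toxicity to these cells at all, and which compound, if any, is the more toxic.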